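Swapping the group on sulfur: compound 3 to compound 4

The source may hold more compounds than are shown below. What is called first, only, known or untested is meant among the compounds shown, and "the series" means these compounds.

Measured so far in a functional assay on DU-145 cells (Homo sapiens) for inhibition, read by trypan blue exclusion, with a stated time of 96 h; a higher number here means a weaker inhibitor of growth, a lower number a stronger inhibitor of growth:
- compound 1 `CCOc1ccc(/C=C(\C(=O)c2ccc(Cl)cc2)S(=O)(=O)Cc2ccc(C)cc2)cc1OC`: 10000 nM
- compound 2 `CCOc1ccc(/C=C(/Sc2ccc(C)cc2)C(=O)c2ccc(Br)cc2)cc1OC`: 50000 nM
- compound 3 `CCOc1ccc(/C=C(/SCc2ccc(C)cc2)C(=O)c2ccc(Cl)cc2)cc1OC`: 25000 nM

Compound 3 gives 25000 nM. That value lies within the usual scatter of compound 2 at 50000 nM, while compound 1 at 10000 nM stands lower, beyond the scatter.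

The next compound is compound 4 `CCOc1ccc(/C=C(/Sc2ccc(C)cc2)C(=O)c2ccc(Cl)cc2)cc1OC`, which has 4-methylphenyl in place of 4-methylbenzyl on a sulfur.

Among the compounds with values here, the only measured step, a 2.5-fold higher number from compound 1 to compound 3 (0.40 log units; beyond the scatter), exchanges (4-methylbenzyl)sulfonyl for (4-methylbenzyl)sulfanyl. It is modest, and it leaves the group now in question untouched, so it bears on this change only indirectly. Within the data shown here, no measured step tests the new change directly. The closest evidence is that compound 2, which also carries (4-methylphenyl)sulfanyl, gives 50000 nM, within the scatter of compound 3. In this assay, therefore, no shift beyond the scatter is expected, with at most a slight drift towards higher numbers.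

The estimated step is a 1.4-fold higher number from compound 3 to compound 4 (0.15 log units; within the scatter).

Compound 4 is estimated at 35000 nM, with an expected range of 15000 nM to 70000 nM.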

Compound 4, concentration for 50% growth inhibition: 25000 nM
For compound 4 the middle estimate is 1.4-fold (0.15 log units) above the measured one; measured number inside the range.
By their numbers in this assay, from the lowest: compound 1; then compounds 3, 4 and 2 (each within the scatter of the next).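

In this assay, exchanging 4-methylbenzyl for 4-methylphenyl on this sulfur gives (no change at the digits printed from compound 3 to compound 4 (within the scatter)), so at this position, with chloro on the aromatic carbon held constant, the two groups cannot be told apart. Compound 4 also supplies a direct reading of the halogen, since chloro in place of bromo on an aromatic carbon gives (a 2.0-fold lower number from compound 2 to compound 4 (0.30 log units; within the scatter)), and with 4-methylphenyl on sulfur that exchange does not separate the two compounds either. The step to a sulfanyl group from the sulfonyl of compound 1 is now seen with two different groups on sulfur, (a 2.5-fold higher number from compound 1 to compound 3 (0.40 log units; beyond the scatter)) and (a 2.5-fold higher number from compound 1 to compound 4 (0.40 log units; beyond the scatter)), so among these compounds only compound 1, the sole sulfonyl, stands apart, and by a modest margin.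

Nothing shown accounts for these values. On these data alone, it remains open whether a sulfonyl carrying 4-methylphenyl would match compound 1, and whether an amine or a carboxylic acid on the group at sulfur, or a longer chain between the sulfur and its aromatic ring, would move the number beyond the scatter.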